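The compounds below may be only part of what the source reports. "The series", "measured", "known", "first", "only" and "open" are said of these compounds alone.

Measured compounds:
compound 1, `O=c1cc(-c2ccc(Cl)c([N+](=O)[O-])c2)oc2ccccc12`: 93800 nM
compound 2, `COc1cc(OC)cc(-c2cc(=O)c3ccccc3o2)c1`: 58800 nM

Both were tested in a functional assay on HepG2 cells (Homo sapiens) for cytotoxicity, read by sulforhodamine B assay, with a stated time of 48 h; a higher number here means a weaker inhibitor of growth, a lower number a stronger inhibitor of growth. The number for compound 1 is the highest of the two, yet compound 2 lies within the usual scatter of it, so the two are not told apart. Each is a weak inhibitor of growth on this cell line.

Compound 3, `O=c1cc(-c2cccc([N+](=O)[O-])c2)oc2ccccc12`, has not yet been measured. It differs from compound 1 in one place: hydrogen in place of chloro on an aromatic carbon. Among the compounds with values here, no pair of measured compounds shows this change, so there is no measured step to lean on. With only weak values at hand, the expectation for this assay is a shift no larger than the scatter, or a small move toward a higher number. Compound 3 is therefore estimated at 110000 nM, within 50000 nM to 250000 nM, which means an expected step of a 1.2-fold higher number from compound 1 to compound 3 (0.07 log units; within the scatter).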

Compound 3, concentration for 50% growth inhibition: 94900 nM
Beside the measured number, compound 3's estimate is 1.2-fold (0.06 log units) above it; low and high end bracket the measured number.
By their numbers in this assay, from the lowest: compounds 2, 1 and 3 (each within the scatter of the next).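

In this assay, swapping chloro for hydrogen gives a 1.0-fold higher number from compound 1 to compound 3 (0.01 log units; within the scatter), so compound 1 and compound 3 are not told apart. Within the data shown here, the earlier compounds offered no pair differing in one place; this pair is the first direct reading at this aromatic carbon, ortho to the nitro group, and it shows that growth inhibition on this cell line stays weak without the chlorine atom. Nothing measured here accounts for this result.

Going by these compounds, whether an amine or a carboxylic acid on this same carbon would give a number beyond the scatter remains open. So does the part played by the nitro group itself, as no pair shown differs only there, and replacing it with an amine would test that directly.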